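The source may hold more compounds than are shown below. What is called first, only, known or untested is meant among the compounds shown, and "the series" means these compounds.

In a functional assay on MDA-MB-453 cells (Homo sapiens) for antiproliferative activity, read by MTT assay, with a stated time of 72 h (on this read-out lower numbers stand for stronger inhibition and higher numbers for weaker inhibition), compound 1 (`Cc1cc(N/C=C2\C(=O)NN=C2c2ccccc2)n[nH]1`) gives 93000 nM and compound 2 (`CCOC(=O)c1c[nH]nc1N/C=C1\C(=O)N(c2ccccc2)N=C1c1ccccc1`) gives 19400 nM, the lower of the two numbers and beyond the scatter. Compound 3 (`Cc1cc(N/C=C2\C(=O)N(c3ccccc3)N=C2c2ccccc2)n[nH]1`) has not been measured. It departs from compound 2 by 5-methyl-1H-pyrazol-3-yl in place of 4-(ethoxycarbonyl)-1H-pyrazol-3-yl on an amine nitrogen, with 5-methyl-1H-pyrazol-3-yl in place of 4-(ethoxycarbonyl)-1H-pyrazol-3-yl on an amine nitrogen. Compound 1, which also carries 5-methyl-1H-pyrazol-3-yl, stands at 93000 nM, so a small move towards weaker inhibition is expected in this assay. The expected change is a 1.8-fold higher number from compound 2 to compound 3 (0.26 log units; within the scatter). For compound 3 the estimated value is 35000 nM, with a range of 12000 nM to 90000 nM.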

Compound 3, half-maximal inhibitory concentration: 10200 nM
Beside the measured number, compound 3's estimate is 3.4-fold (0.54 log units) above it; the whole stated range lies above it.
By their numbers in this assay, from the lowest: compounds 3 and 2 (each within the scatter of the next); then compound 1.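

In this assay the exchange on the amine nitrogen gives a 1.9-fold lower number from compound 2 to compound 3 (0.28 log units; within the scatter), so at this place the read-out does not separate 5-methyl-1H-pyrazol-3-yl from 4-(ethoxycarbonyl)-1H-pyrazol-3-yl. Phenyl on the amide-type nitrogen in a ring gives a 9.1-fold lower number from compound 1 to compound 3 (0.96 log units; beyond the scatter), and of these two steps only this one is beyond the scatter. Nothing given here explains either step. The compounds shown leave open how a pyrazole carrying an amine or a carboxylic acid would read on the amine nitrogen. They also leave open whether a benzyl group on the amide-type nitrogen would match phenyl.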